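Biaryl amide series: cyano substitution on the anilide ring

A few compounds are considered here, and "the series" means these few. Any claim that something is new, unique, unknown or untested is made for them only; others in the source may bear on it.

Compound 1 `C[C@@H]1CN(c2ncccc2C(F)(F)F)CCN1C(=O)Nc1ccc(C(F)(F)F)cc1`, 11 nM in a functional assay for antagonist activity at transient receptor potential cation channel subfamily V member 1 (Rattus norvegicus); on this read-out higher numbers stand for weaker inhibition and lower numbers for stronger inhibition. Compound 2 `O=C(Nc1ccccc1)c1ccc(-c2ncccc2C(F)(F)F)cc1`, "not determined" (no result reported) in this assay.

Within the data shown here, compound 1 is the only member with a number in this assay. Compound 2 carries the biaryl amide core and stands without any value, so its position relative to compound 1 cannot be placed. Compound 3 `N#Cc1ccc(NC(=O)c2ccc(-c3ncccc3C(F)(F)F)cc2)cc1` differs from compound 2 by cyano in place of hydrogen on an aromatic carbon. Among the measured compounds shown here, with no comparable pair measured, no step size or direction can be drawn from the data; a shift not beyond the scatter is expected. Compound 3 is estimated at 50 nM, with a range from 5 nM to 500 nM.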

Compound 3, half-maximal inhibitory concentration: 1300 nM
For compound 3 the middle estimate is 26-fold (1.41 log units) below the measured one; the whole stated range lies below it.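

No step can be read between compound 2 and compound 3, so compound 3 stands alone in the series. The compounds shown leave open how cyano in place of hydrogen shifts inhibition. No evidence at hand bears on this result.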